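The compounds below may be only part of what the source reports. "The series", "measured", "known", "first", "only" and "open" are said of these compounds alone.

Measured so far:
compound 1, `CN1C[C@H](C(=O)Nc2ccc(F)c(F)c2)[C@@H](c2ccc(/C=C/C(=O)Nc3ccccc3N)cc2)C1`: 29%
compound 2, `CC(C)N1C[C@H](C(=O)Nc2ccc(Cl)cc2)[C@@H](c2ccc(/C=C/C(=O)Nc3ccccc3N)cc2)C1`: 100%

Of the compounds shown here, two of a shared core have been tested in an in vivo ADME assay on the whole organism (strain BALB/C) for pharmacokinetics, with Mus musculus as the target, read by LC-MS, at a dose of 10 mg/kg by the oral route; a lower number here means that a smaller share of the oral dose reaches the circulation, a higher number that a larger share of the oral dose reaches the circulation. In this assay compound 2 gives 100%, the highest of the two numbers. In this assay compound 1 gives 29%, a number that sits well below compound 2, by a margin beyond the usual scatter of repeated measurements. The two compounds differ in more than one place, so no single structural change can be read from that gap.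

Compound 3, `Nc1ccccc1NC(=O)/C=C/c1ccc([C@H]2CN(C3CCOCC3)C[C@@H]2C(=O)Nc2ccc(Cl)cc2)cc1`, has not yet been measured. It is built from compound 2 by one change: oxan-4-yl in place of isopropyl on an amine nitrogen in a ring. Going by the values given here, no measured pair of compounds that differ only in this one place exists, so the size of the step cannot be taken from known numbers. With compound 2 already at the top of the measured range, the expected step from compound 2 to compound 3 is a modest decrease, a number 30 percentage points lower from compound 2 to compound 3 (beyond the scatter), in this assay. For compound 3 the expected value in this assay is 70%, within a range from 35% to 100%.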

Compound 3, oral bioavailability: 23%
Compound 3: the middle estimate sits 47 percentage points above what was measured; the whole stated range lies above it.
By their numbers in this assay, from the lowest: compounds 3 and 1 (each within the scatter of the next); then compound 2.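

Going by these compounds alone, compound 2 and compound 3 are the first pair here that differ in one place only, so this step can be read directly. In this assay, putting oxan-4-yl in place of isopropyl on the amine nitrogen in a ring gives a number 77 percentage points lower from compound 2 to compound 3 (beyond the scatter), a large step for a single exchange with the rest of the structure unchanged. This shows that the result in this assay is sensitive to the group at this position, which the earlier pair could not show since its compounds differ in more than one place. Nothing measured here explains why the exchange has this effect.

Going by these compounds, the exchange brings in both a six-membered non-aromatic ring and a ring oxygen, so it remains open which of the two goes with the lower number; a cyclohexyl group, which has the ring without the oxygen, would separate them. Also open, on these data alone, is where a cyclopropyl group on this nitrogen would fall, and whether a step of this size would recur with a different group in place of the (4-chlorophenyl)carbamoyl group.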